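Methylation of an aromatic hydroxyl on a macrocyclic core

A few compounds are considered here, and "the series" means these few. Any claim that something is new, unique, unknown or untested is made for them only; others in the source may bear on it.

Of the compounds shown here, three sharing one macrocyclic core have been measured in a functional assay on KPL4 cells (Homo sapiens) for inhibition; a lower number here means a stronger inhibitor of growth, a higher number a weaker inhibitor of growth. Compound 1 `CO[C@H]1C[C@H](C)Cc2cc(O)cc(c2)NC(=O)/C=C/CC[C@H](OC)[C@@H](OC(N)=O)/C(C)=C/[C@H](C)[C@H]1O` gives 3390 nM in this assay. Compound 2 `COc1c2cc(cc1OC(C)=O)NC(=O)/C(C)=C/CC[C@H](OC)[C@@H](OC(N)=O)/C(C)=C/[C@H](C)[C@@H](O)[C@@H](OC)C[C@H](C)C2` gives 180 nM, and compound 3 `CO[C@H]1C[C@H](C)Cc2cc(cc(O)c2O)NC(=O)/C(C)=C/CC[C@H](OC)[C@@H](OC(N)=O)/C(C)=C/[C@H](C)[C@H]1O` gives 4330 nM. Compound 3 therefore stands at the highest number of the three; its nearest neighbour is compound 1, whose number lies within the scatter of its own, while compound 2 sits far lower, beyond the scatter.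

Compound 4 `COc1c(O)cc2cc1C[C@@H](C)C[C@H](OC)[C@H](O)[C@@H](C)/C=C(\C)[C@H](OC(N)=O)[C@@H](OC)CC/C=C(\C)C(=O)N2` is not yet measured. It differs from compound 3 in one place: methyl in place of hydrogen on an oxygen on an aromatic ring. Among the compounds with values here, no step between two measured compounds of this set is documented, so the effect of this exchange cannot be read from a precedent here. Compound 4 is expected to land at a somewhat lower number than compound 3, a step of a 2.4-fold lower number from compound 3 to compound 4 (0.38 log units; beyond the scatter) in this assay, though the shift may well stay within the scatter. The estimate for compound 4 is 1800 nM, with a range from 400 nM to 6000 nM.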

Compound 4, concentration for 50% growth inhibition: 450 nM
For compound 4 the middle estimate is 4.0-fold (0.60 log units) above the measured one; low and high end bracket the measured number.
By their numbers in this assay, from the lowest: compound 2; then compound 4; then compounds 1 and 3 (each within the scatter of the next).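

In this assay, within the data shown here, methyl in place of hydrogen on an oxygen on an aromatic ring gives a 9.6-fold lower number from compound 3 to compound 4 (0.98 log units; beyond the scatter), the first documented step on the shared core, which shows that this hydroxy to methoxy exchange is not a silent change at this position. The remaining aromatic hydroxy of compound 4 also responds to substitution: with hydrogen in place of acetyl on that oxygen, the step is a 2.5-fold higher number from compound 2 to compound 4 (0.40 log units; beyond the scatter). Across these two steps, the compound with the free hydroxy has the higher number each time, and both steps lie beyond the scatter.

The compounds shown leave open whether a longer chain such as ethyl on the same oxygen, or an amine in place of the hydroxy, would move the number in the same direction. Nothing shown here explains why the number moves with either exchange.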